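A few compounds are considered here, and "the series" means these few. Any claim that something is new, unique, unknown or untested is made for them only; others in the source may bear on it.

Compound 1, `CC1=C(/C=C/C(=O)/C=C/c2ccccc2)C(C)(C)CCC1O`: 5800 nM
Compound 2, `CC1=C(/C=C/C(=O)/C=C/c2cccc(F)c2)C(C)(C)CCC1O`: 4400 nM
Compound 3, `CC1=C(/C=C/C(=O)/C=C/c2cccc(C)c2)C(C)(C)CCC1O`: 4100 nM

These three numbers come from a functional assay on LNCaP cells (Homo sapiens) for cytotoxicity, read by MTT assay, with a stated time of 72 h; a lower number here means a stronger inhibitor, a higher number a weaker inhibitor. Compound 3 shows the lowest of them, yet all three sit within the scatter of one another: a 1.4-fold lower number from compound 1 to compound 3 (0.15 log units; within the scatter) and a 1.1-fold lower number from compound 2 to compound 3 (0.03 log units; within the scatter). Compound 4, `CC1=C(/C=C/C(=O)/C=C/c2cccc(C#N)c2)C(C)(C)CCC1O`, differs from compound 3 by cyano in place of methyl on an aromatic carbon. Going by the values given here, no measured step exchanges a methyl for a cyano. The steps that changed a group on an aromatic carbon, a 1.3-fold lower number from compound 1 to compound 2 (0.12 log units; within the scatter), a 1.4-fold lower number from compound 1 to compound 3 (0.15 log units; within the scatter) and a 1.1-fold lower number from compound 2 to compound 3 (0.03 log units; within the scatter), all stayed within the scatter. A further swap there is therefore expected to give no step beyond the scatter in this assay, that is a 1.1-fold higher number from compound 3 to compound 4 (0.04 log units; within the scatter). Compound 4 is estimated at 4500 nM, with a range from 2000 nM to 10000 nM.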

Compound 4, half-maximal inhibitory concentration: 1800 nM
For compound 4 the middle estimate is 2.5-fold (0.40 log units) above the measured one; the whole stated range lies above it.
By their numbers in this assay, from the lowest: compound 4; then compounds 3, 2 and 1 (each within the scatter of the next).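

In this assay, going by these compounds alone, the steps of a 2.3-fold lower number from compound 3 to compound 4 (0.36 log units; beyond the scatter) and a 2.4-fold lower number from compound 2 to compound 4 (0.39 log units; beyond the scatter) and also a 3.2-fold lower number from compound 1 to compound 4 (0.51 log units; beyond the scatter) are the first here to pass beyond the scatter, though all are modest. Hydrogen, fluoro and methyl could not be told apart at this position, so the position does respond to what sits on it, and cyano is the one group that stands apart. Nothing measured here explains why cyano differs from the other groups. As far as these compounds go, whether an amine, a carboxylic acid or a methoxy group at this position would match cyano stays open. From the compounds shown here alone, whether a cyano group on another place of the same ring would do the same also stays open.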